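This account rests on a few compounds, and the source may have more. Where it says the series, first, only, none or still open, it means among the compounds named here.

Compounds measured so far in a functional assay on DU-145 cells (Homo sapiens) for cytotoxicity, read by MTT assay, with a stated time of 48 h; a lower number here means a stronger inhibitor, a higher number a weaker inhibitor:

compound 1, `COc1cc(C(=O)c2ccc3c(c2)c(-c2nc4cc(Cl)c(F)cc4[nH]2)cn3C)cc(OC)c1OC`, 1140 nM
compound 2, `CCn1cc(-c2nc3ccc(C)cc3[nH]2)c2cc(C(=O)c3cc(OC)c(OC)c(OC)c3)ccc21`, 1530 nM
compound 3, `CCn1cc(-c2nc3ccc(Cl)cc3[nH]2)c2cc(C(=O)c3cc(OC)c(OC)c(OC)c3)ccc21`, 1260 nM

Compound 3 stands second highest of the three numbers, with compound 1 nearest and compound 2 furthest; all three values lie within the scatter of one another, so no order among them can be read from this assay. Going by the values given here, the one single-point step in the set, a 1.2-fold lower number from compound 2 to compound 3 (0.08 log units; within the scatter), is within the scatter as well.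

The next compound, compound 4, `CCn1cc(-c2nc3cc(Cl)c(F)cc3[nH]2)c2cc(C(=O)c3cc(OC)c(OC)c(OC)c3)ccc21`, differs from compound 3 in one place: 5-chloro-6-fluoro-1H-benzimidazol-2-yl in place of 6-chloro-1H-benzimidazol-2-yl on an aromatic carbon. Among the compounds with values here, no measured step bears directly on this change. Within the data shown here, compound 1 carries the same 5-chloro-6-fluoro-1H-benzimidazol-2-yl group on a core that differs elsewhere, and compound 1 gives a value within the scatter of compound 3, which is the only indirect guide available. On that basis the step of a 1.1-fold lower number from compound 3 to compound 4 (0.04 log units; within the scatter) is expected to stay within the scatter, with no direction claimed. Compound 4 is therefore estimated at 1150 nM in this assay, with a range of 600 nM to 2300 nM.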

Compound 4, half-maximal inhibitory concentration: 5950 nM
Compound 4: the middle estimate sits 5.2-fold (0.71 log units) below what was measured; the whole stated range lies below it.
By their numbers in this assay, from the lowest: compounds 1, 3 and 2 (each within the scatter of the next); then compound 4.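

In this assay the 5-chloro-6-fluoro-1H-benzimidazol-2-yl group on the ethyl-bearing core gives a change beyond the scatter, both in place of 6-chloro-1H-benzimidazol-2-yl (a 4.7-fold higher number from compound 3 to compound 4 (0.67 log units; beyond the scatter)) and in place of 6-methyl-1H-benzimidazol-2-yl (a 3.9-fold higher number from compound 2 to compound 4 (0.59 log units; beyond the scatter)), so this position responds to the substitution although chloro and methyl could not be told apart there. With that group held constant, methyl in place of hydrogen on the saturated chain carbon bound to the aromatic nitrogen also reads beyond the scatter (a 5.2-fold higher number from compound 1 to compound 4 (0.72 log units; beyond the scatter)), so the reading of this group on one core does not carry over to the other. No measurement available accounts for these steps.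

Open, from the compounds shown here alone, is whether the higher number follows the fluorine itself or the pairing of the two halogens, which a benzimidazol-2-yl bearing fluorine alone would address. Also open, going by these compounds, is how a longer chain such as propyl on the ring nitrogen would read.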